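The source may report more compounds than this note shows. Statements on the series, on what has been measured and on what is new or still open speak of the compounds shown alone.

Working notes on the series. In an assay on CHO cells for antagonist activity at transient receptor potential cation channel subfamily V member 1 (Homo sapiens), read by FLIPR (on this read-out lower numbers stand for stronger inhibition and higher numbers for weaker inhibition), compound 2 `CC(C(=O)NCc1ccc(C(F)(F)F)cc1N1CCN(C2CCCCC2)CC1)c1ccc(NS(C)(=O)=O)c(F)c1` stands highest of the three numbers, at 13.8 nM. Compound 3 `COc1ccc(N2CCN(c3cc(C(F)(F)F)ccc3CNC(=O)C(C)c3ccc(NS(C)(=O)=O)c(F)c3)CC2)cc1` gives 1.6 nM in this assay, and compound 1 `CC(C(=O)NCc1ccc(C(F)(F)F)cc1N1CCC(Cc2ccc(F)cc2)CC1)c1ccc(NS(C)(=O)=O)c(F)c1` gives 0.4 nM. Going by the values given here, the only measured step that alters a single place is an 8.6-fold lower number from compound 2 to compound 3 (0.94 log units; beyond the scatter), with 4-methoxyphenyl in place of cyclohexyl on an amine nitrogen in a ring; compound 1 against compound 2 is a comparison of two values only, with no single-place step between them.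

Compound 4 `CC(C(=O)NCc1ccc(C(F)(F)F)cc1SC1CCCCC1)c1ccc(NS(C)(=O)=O)c(F)c1` is not yet measured. Its change from compound 2 is cyclohexylsulfanyl in place of 4-cyclohexylpiperazin-1-yl on an aromatic carbon. Among the compounds with values here, no measured step concerns removal of the 4-cyclohexylpiperazin-1-yl group itself; the step from compound 2 to compound 3 keeps that ring and only swaps the group on its nitrogen, so it bears on this change only indirectly. The whole range of measured numbers is spanned by groups that keep a six-membered ring with nitrogen at this aromatic carbon, and compound 4 leaves that pattern. A step toward a higher number is expected for compound 4, of the size a 2.9-fold higher number from compound 2 to compound 4 (0.46 log units; beyond the scatter). In this assay compound 4 is expected to give about 40 nM, within a range of 4 nM to 400 nM.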

Compound 4, inhibition constant: 0.5 nM
Beside the measured number, compound 4's estimate is 80-fold (1.90 log units) above it, and the stated range ends above it.
By their numbers in this assay, from the lowest: compounds 1 and 4 (each within the scatter of the next); then compound 3; then compound 2.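

In this assay, the step of a 28-fold lower number from compound 2 to compound 4 (1.44 log units; beyond the scatter) shows that this aromatic carbon does not need a six-membered ring with nitrogen, as cyclohexylsulfanyl, which holds sulfur and no nitrogen, replaces 4-cyclohexylpiperazin-1-yl and inhibition becomes stronger. The earlier step of an 8.6-fold lower number from compound 2 to compound 3 (0.94 log units; beyond the scatter) kept that ring and changed only the group on its nitrogen, so it could not show that the ring itself can be given up at this position. No measurement at hand accounts for the size of the new step.

Still open, going by these compounds, is whether cyclohexyloxy, with oxygen as the link, or phenylsulfanyl, with an aromatic ring on the sulfur, would hold the number at this carbon. The change from compound 2 to compound 4 alters both the linking atom and the number of heavy atoms, and the compounds shown do not separate the two.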